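Replacing the aminocyclohexyl ring with an acyclic chain

The compounds below may be only part of what the source reports. "The series", "measured", "known", "first", "only" and "open" are said of these compounds alone.

Among the three compounds measured so far, compound 3 `N[C@H]1CC[C@H](N(C[C@H]2Cc3ccccc3CN2)[C@H]2CCCc3cccnc32)CC1` stands lowest: in a functional assay on CCRF-CEM cells for antagonist activity at C-X-C chemokine receptor type 4 (Homo sapiens), read by calcium flux, with stated times of 25 min and 90 s (on this read-out lower numbers stand for stronger inhibition and higher numbers for weaker inhibition), compound 3 gives 34 nM. Compound 1 `C/C(CN(C[C@H]1Cc2ccccc2CN1)[C@H]1CCCc2cccnc21)=C(\F)CN` gives 80 nM in this assay, and compound 2 `N[C@H]1CC[C@@H](N(C[C@H]2Cc3ccccc3CN2)[C@H]2CCCc3cccnc32)CC1` gives 1800 nM. The steps of a 2.4-fold lower number from compound 1 to compound 3 (0.37 log units; beyond the scatter) and a 23-fold higher number from compound 1 to compound 2 (1.35 log units; beyond the scatter) both put a 4-aminocyclohexyl group in place of the 4-amino-3-fluoro-2-methylbut-2-en-1-yl group on the amine nitrogen, yet they run in opposite directions because the fact that compounds 2 and 3 differ only in the configuration as drawn and the step of a 53-fold lower number from compound 2 to compound 3 (1.72 log units; beyond the scatter) show that the drawn configuration alone moves the number by a large amount.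

Compound 4 `C/C(=C/CN(C[C@H]1Cc2ccccc2CN1)[C@H]1CCCc2cccnc21)CN` has not yet been measured. It differs from compound 3 in a group of 6 heavy atoms (5 carbon, 1 nitrogen; no ring) in place of a group of 7 heavy atoms (6 carbon, 1 nitrogen; one six-membered non-aromatic ring of carbon only), on an amine nitrogen. The entering chain resembles the chain of compound 1, lacking only the fluorine. The measured step that bears most on this change is a 2.4-fold lower number from compound 1 to compound 3 (0.37 log units; beyond the scatter), a modest step in the opposite direction; compound 2 does not apply, since its ring configuration differs. Undoing that step is expected to give a modest rise in the number, so the expected step is a 2.9-fold higher number from compound 3 to compound 4 (0.47 log units; beyond the scatter). Compound 4 is therefore expected to give about 100 nM in this assay, within a range from 40 nM to 300 nM.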

Compound 4, half-maximal inhibitory concentration: 8.6 nM
Compound 4: the middle estimate sits 12-fold (1.07 log units) above what was measured; the whole stated range lies above it.
By their numbers in this assay, from the lowest: compound 4; then compound 3; then compound 1; then compound 2.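

The result shows that the position on the amine nitrogen needs no ring: in this assay the open chain of compound 4 gives a 4.0-fold lower number from compound 3 to compound 4 (0.60 log units; beyond the scatter) on the 4-aminocyclohexyl group of the better ring compound, so the ring is not required for the lowest number among these compounds. The same change gives a 210-fold lower number from compound 2 to compound 4 (2.32 log units; beyond the scatter) and thus a much larger step, and the gap between these two steps comes from the ring alone, because the two ring compounds are separated only by the following: the fact that compounds 2 and 3 differ only in the configuration as drawn. The open chains also differ clearly from each other, with a 9.3-fold lower number from compound 1 to compound 4 (0.97 log units; beyond the scatter) on the same saturated chain carbon, which shows that the number responds to the detail of the chain and not just to the absence of a ring, though this step is more than the loss of fluorine, since the methyl group also sits differently in the two chains.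

The compounds shown leave open which feature of the chain in compound 4 matters, since the fluorine and the methyl placement change together. They also leave open how a fully saturated aminobutyl chain or a longer chain ending in an amine would compare with it.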